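This account rests on a few compounds, and the source may have more. Where it says the series, first, only, none or still open, it means among the compounds named here.

Measured compounds:
- compound 1, `COc1ccc(SCc2ccc(/C=C/C(=O)Nc3ccccc3N)cc2)cc1OC`: 21.9%
- compound 2, `Nc1ccccc1NC(=O)c1ccc(CSc2nccc(C(F)(F)F)n2)cc1`: 83.4%

In a functional assay on HeLa cells (Homo sapiens) for inhibition, read by CCK-8 assay, with a stated time of 72 h, tested at 8 uM (on this read-out lower numbers stand for less inhibition of growth and higher numbers for more inhibition of growth at the one concentration tested), compound 1 gives 21.9%, the lowest of the two numbers recorded. Within the data shown here, compound 2 gives 83.4%, a number far above compound 1, beyond the scatter; no step is recorded between these two, and they differ in more than one place, so only their two values stand side by side.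

Compound 3, `Nc1ccccc1NC(=O)/C=C/c1ccc(CSCCc2ccccc2)cc1`, has not been measured in this assay. It differs from compound 1 in one place: phenethyl in place of 3,4-dimethoxyphenyl on a sulfur. The shared core of compound 1, with its amide and the aminophenyl group on the nitrogen, is kept unchanged. Among the measured compounds shown here, with no recorded step to guide the size of the change, a step within the scatter, or a small one in either direction, is expected; the estimated step of a number 6.1 percentage points higher from compound 1 to compound 3 (within the scatter) reflects this. Compound 3 is therefore estimated at 28%, with a range from 10% to 50%.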

Compound 3, percent growth inhibition at one concentration: 3.57%
The estimate for compound 3 lay 24.4 percentage points above the measured number; the whole stated range lies above it.
By their numbers in this assay, from the lowest: compound 3; then compound 1; then compound 2.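

In this assay the group on this sulfur matters even with the rest of compound 1 kept unchanged: phenethyl in place of 3,4-dimethoxyphenyl gives a number 18.3 percentage points lower from compound 1 to compound 3 (beyond the scatter) and takes the number further from that of compound 2. The change removes 2 hydrogen-bond acceptors and alters the group in other ways, and this single step cannot show which difference counts. No measurement offered here accounts for the step.

The compounds shown leave open whether a single methoxy group on the phenyl ring, an amine or a carboxylic acid at the end of the phenethyl chain, or a longer chain would raise or lower the number. They also leave open whether the same change would have a similar effect on the core of compound 2.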